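Replacing a Pyridinyloxy Group with an Isobutyramide

A few compounds are considered here, and "the series" means these few. Any claim that something is new, unique, unknown or untested is made for them only; others in the source may bear on it.

Compound 1, `O=C(O)c1ccc2noc(-c3ccc(Cc4ccccc4)cc3)c2c1`, gives 1290 nM in an assay for inhibition of inositol hexakisphosphate kinase 3 (Homo sapiens), read by colorimetric assay, coupled enzyme assay and malachite green, with a stated time of 120 min, in the presence of a further agent that is not named here; on this read-out higher numbers stand for weaker inhibition and lower numbers for stronger inhibition.
Compound 2, `O=C(O)c1ccc2noc(-c3ccc(Oc4ccccc4)cc3)c2c1`, gives 550 nM in this assay.
Compound 3, `O=C(O)c1ccc2noc(-c3ccc(Oc4ccccn4)cc3)c2c1`, gives 2060 nM in this assay.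

Compound 3 stands at the weaker end of these three numbers: a 1.6-fold higher number from compound 1 to compound 3 (0.20 log units; within the scatter), which lies within the scatter, whereas a 3.7-fold higher number from compound 2 to compound 3 (0.57 log units; beyond the scatter) lies beyond it. Compound 4, `CC(C)C(=O)Nc1ccc(-c2onc3ccc(C(=O)O)cc23)cc1`, differs from compound 3 by (isopropylcarbonyl)amino in place of (pyridin-2-yl)oxy on an aromatic carbon. For the measured compounds named here, no measured step introduces an amide at this place; the steps of a 2.3-fold lower number from compound 1 to compound 2 (0.37 log units; beyond the scatter) and a 3.7-fold higher number from compound 2 to compound 3 (0.57 log units; beyond the scatter) show only that exchanges there move the number modestly, in either direction. The step of a 1.4-fold lower number from compound 3 to compound 4 (0.14 log units; within the scatter) is therefore expected to be small, with no clear direction. For compound 4 the estimated value in this assay is 1500 nM, within a range from 400 nM to 5000 nM.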

Compound 4, half-maximal inhibitory concentration: 210 nM
Compound 4: the middle estimate sits 7.1-fold (0.85 log units) above what was measured; measured number below the stated range.
By their numbers in this assay, from the lowest: compound 4; then compound 2; then compounds 1 and 3 (each within the scatter of the next).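

In this assay the (isopropylcarbonyl)amino group, which has no ring, gives a lower number than all three ring-bearing groups on this aromatic carbon: the steps are a 9.8-fold lower number from compound 3 to compound 4 (0.99 log units; beyond the scatter) and a 2.6-fold lower number from compound 2 to compound 4 (0.42 log units; beyond the scatter) and a 6.1-fold lower number from compound 1 to compound 4 (0.79 log units; beyond the scatter) against the (pyridin-2-yl)oxy, phenoxy and benzyl groups in that order. A second aromatic ring at this place is thus not needed for the lowest number of the four, which compound 4 holds. Nothing at hand explains this drop.

The compounds shown leave open whether the amide hydrogen or the isopropyl branch carries the step. An acetyl amide, a cyclopropyl amide or a plain amine on this carbon would separate these parts.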